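A Thiophene Replaces the Fluorophenyl Arm

A few compounds are considered here, and "the series" means these few. Any claim that something is new, unique, unknown or untested is made for them only; others in the source may bear on it.

Within the data shown here, in a functional assay on MKN-45 cells (Homo sapiens) for inhibition, with a stated time of 72 h (a higher number here means a weaker inhibitor, a lower number a stronger inhibitor), compound 2 `COc1ccc(S(=O)(=O)N2CCc3cccc(-c4ccc(F)cc4)c32)cc1` gives 79 nM, the highest number of the three measured so far, though its gap to compound 3 lies within the scatter. Compound 3 `COc1ccc(S(=O)(=O)N2CCc3cccc(-c4ccc(F)c(F)c4)c32)cc1` gives 55.5 nM, and compound 1 `COc1ccc(S(=O)(=O)N2CCc3cccc(-c4ccc([N+](=O)[O-])cc4)c32)cc1` gives 34 nM. The step of a 2.3-fold higher number from compound 1 to compound 2 (0.37 log units; beyond the scatter) is the only one beyond the scatter; the step of a 1.4-fold lower number from compound 2 to compound 3 (0.15 log units; within the scatter) is not. Compound 4 `COc1ccc(S(=O)(=O)N2CCc3cccc(-c4cccs4)c32)cc1` differs from compound 2 by thiophen-2-yl in place of 4-fluorophenyl on an aromatic carbon. Both measured steps concern fluoro and nitro groups rather than the exchange of one ring for another, and neither points to a large shift. The expected outcome is a step of a 1.1-fold higher number from compound 2 to compound 4 (0.06 log units; within the scatter), within the scatter. Compound 4 is estimated at 90 nM, in a range from 40 nM to 200 nM.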

Compound 4, half-maximal inhibitory concentration: 165 nM
Compound 4: middle estimate off by 1.8-fold (0.26 log units), on the low side; measured number inside the range.
By their numbers in this assay, from the lowest: compounds 1, 3 and 2 (each within the scatter of the next, the first and the last beyond it); then compound 4.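

In this assay this position on the fused ring system responds more to replacing the whole ring than to changing the substituents on the phenyl ring (a 2.1-fold higher number from compound 2 to compound 4 (0.32 log units; beyond the scatter)). Thiophen-2-yl gives a higher number than each of the other arms (a 3.0-fold higher number from compound 3 to compound 4 (0.47 log units; beyond the scatter); a 4.9-fold higher number from compound 1 to compound 4 (0.69 log units; beyond the scatter)). Nothing available here accounts for this change. The compounds shown leave open whether the shift follows the sulfur atom or the five-membered ring. A furan-2-yl or pyridin-3-yl arm could separate those two readings, and thiophen-3-yl could test how the ring's attachment matters.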